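Lengthening the Chain on the Shared Core

The compounds below may be only part of what the source reports. "The series", "measured", "known", "first", "only" and "open" are said of these compounds alone.

Compound 1 `CCCCCCCn1cc(COC[C@@H]2OC[C@H](N)[C@@H]2O)nn1` carries a heptyl chain on the shared core. In a functional assay on EC9706 cells (Homo sapiens) for antiproliferative activity, read by MTT assay, with a stated time of 48 h (a higher number here means a weaker inhibitor, a lower number a stronger inhibitor), compound 1 gives > 128000 nM, which is a limit of the assay rather than a measured number. Compound 2 `CCCCCCCCCCCCn1cc(COC[C@@H]2OC[C@H](N)[C@@H]2O)nn1` extends that chain, and in this assay compound 2 gives 16000 nM. For the measured compounds named here, the step of an at least 8.0-fold lower number from compound 1 to compound 2 (0.90 log units; beyond the scatter) is the only measured step available, and it relates to the limit of > 128000 nM in this assay, at which 1 of the 2 values shown sits. Compound 3 `CCCCCCCCCCCCCCCCCCn1cc(COC[C@@H]2OC[C@H](N)[C@@H]2O)nn1` is not yet measured; it differs from compound 1 by undecyl in place of hydrogen on a saturated chain carbon, seven bonds along the chain from an aromatic nitrogen. Going by the values given here, the one measured step points toward a lower number with a longer chain, and the change in compound 3 goes further along the same chain, so a number below that of compound 2 is expected, though with wide uncertainty since only one step supports it. The expected step is an at least 21-fold lower number from compound 1 to compound 3 (1.32 log units; beyond the scatter). Compound 3 is therefore estimated at 6000 nM, within 1500 nM to 30000 nM.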

Compound 3, half-maximal inhibitory concentration: 17800 nM
Compound 3: the middle estimate sits 3.0-fold (0.47 log units) below what was measured, within the range that was stated.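

For the compounds shown here, the undecyl change still gives an at least 7.1-fold lower number from compound 1 to compound 3 (0.85 log units; beyond the scatter) in this assay, but that size is only a floor, since compound 1 has a limit and not a number: the limit of > 128000 nM in this assay, at which 1 of the 3 values shown sits. What the earlier compounds could not show lies further along the chain, where the added hexyl gives a 1.1-fold higher number from compound 2 to compound 3 (0.05 log units; within the scatter), so the two values cannot be told apart. Among these three chains, the lower number reached with the first lengthening is therefore not carried further by the second.

The compounds shown leave open how the numbers behave for chains of other lengths, and how large the true gap to compound 1 is. They also leave open whether a chain ending in an amine or a carboxylic acid would give a different number in this assay.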